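From Compound 2 to Compound 3: a Nitrophenyl Exchange

This account rests on a few compounds, and the source may have more. Where it says the series, first, only, none or still open, it means among the compounds named here.

Going by the values given here, compound 2 `COc1cc2c(Oc3ccc(NC(=O)c4nn(-c5ccccc5F)c(=O)c5ccccc45)cc3F)ccnc2cc1OCCCN1CCCCC1` gives 910 nM in a functional assay on MDA-MB-231 cells (Homo sapiens) for cytotoxicity, read by MTT assay, with a stated time of 72 h (on this read-out lower numbers stand for stronger inhibition and higher numbers for weaker inhibition), the lower of the two numbers known so far. Compound 1 `COc1cc2c(Oc3ccc(NC(=O)c4nn(-c5ccc([N+](=O)[O-])cc5)c(=O)c5ccccc45)cc3F)ccnc2cc1OCCCN1CCN(C)CC1` gives 3490 nM in this assay, a gap beyond the scatter, but the two compounds differ in two places, so the gap is not credited to either change alone. Compound 3 `COc1cc2c(Oc3ccc(NC(=O)c4nn(-c5ccc([N+](=O)[O-])cc5)c(=O)c5ccccc45)cc3F)ccnc2cc1OCCCN1CCCCC1` follows from compound 2 by 4-nitrophenyl in place of 2-fluorophenyl on an aromatic nitrogen. Among the compounds with values here, with no measured step for this change, the chemist expects a modest weakening, the expected step being a 2.0-fold higher number from compound 2 to compound 3 (0.30 log units; within the scatter). For compound 3 the estimate is 1800 nM, with a range of 600 nM to 5400 nM.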

Compound 3, half-maximal inhibitory concentration: 2620 nM
Compound 3: the middle estimate sits 1.5-fold (0.16 log units) below what was measured, and the stated range covers the measured number.
By their numbers in this assay, from the lowest: compound 2; then compounds 3 and 1 (each within the scatter of the next).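

In this assay the exchange on the aromatic nitrogen now stands alone: 4-nitrophenyl in place of 2-fluorophenyl gives a 2.9-fold higher number from compound 2 to compound 3 (0.46 log units; beyond the scatter) with the rest of the structure unchanged. Piperidin-1-yl in place of 4-methylpiperazin-1-yl on the saturated chain carbon gives a 1.3-fold lower number from compound 1 to compound 3 (0.12 log units; within the scatter), so of the two places where compound 1 and compound 2 differ, only the exchange on the aromatic nitrogen has a step beyond the scatter. No measurement at hand gives a reason for either step. The compounds shown leave open whether the step follows the nitro group or its place on the ring, which 4-fluorophenyl and 2-nitrophenyl would separate. On these data alone, how an amine, as in 4-aminophenyl, would read on that nitrogen also remains open.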